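The source may hold more compounds than are shown below. What is called first, only, known or untested is meant among the compounds shown, and "the series" means these compounds.

Within the data shown here, compound 3 `COc1ccc(CNc2nc(Cl)nc(-c3ccco3)c2NC=O)cc1` is the only member of this small set for which a result is given. In an ADME assay on Vero cells (Chlorocebus sabaeus) for cytotoxicity, read by MTT assay, with a stated time of 72 h (on this read-out lower numbers stand for stronger inhibition and higher numbers for weaker inhibition), compound 3 gives > 40 ug/mL, and this is a limit of the assay rather than a number. Compound 3 thus sits at the limit of > 40 ug/mL in this assay, at which 1 of the 3 values shown sits. Compound 1 `COc1ccc(CNc2cc(-c3ccco3)nc(Cl)n2)cc1` carries, in this assay, the entry "not determined" (no result reported). Compound 2 `COc1ccc(CNc2ncnc(-c3ccco3)c2[N+](=O)[O-])cc1` carries, in this assay, the entry "not determined" (no result reported). Among the measured compounds shown here, no two measured compounds differ in a single place, so no measured step exists to show how a change of this kind moves the read-out.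

Compound 4 `COc1ccc(CNc2nc(OC)nc(-c3ccco3)c2NC=O)cc1` differs from compound 3 by methoxy in place of chloro on an aromatic carbon, on the ring carbon between two ring nitrogen atoms of the shared core. For the measured compounds named here, with only a limit for compound 3 and no measured step to lean on, the step in this assay is expected to be none beyond the scatter, and compound 4 is expected to land in the same region as that limit. Compound 4 is therefore expected to give an estimated 50 ug/mL in this assay, within a range from 25 ug/mL to 120 ug/mL. The estimated step that the limit leaves unreadable from compound 3 to compound 4 is expected to be small.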

Compound 4, half-maximal inhibitory concentration: > 40 ug/mL
Compound 4 gave a limit, no number; the forecaster's own chance of this, stated with the estimate: 80%; the middle value does not contradict the limit.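

No new step can be read between compound 3 and compound 4, since both results in this assay are limits and not numbers: the limit of > 40 ug/mL in this assay, at which 2 of the 4 values shown sit. The compounds shown leave open how far, in this assay, methoxy in place of chloro on an aromatic carbon moves the read-out, and what single number either compound would give.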